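A few compounds are considered here, and "the series" means these few. Any claim that something is new, unique, unknown or untested is made for them only; others in the source may bear on it.

Within the data shown here, compound 1, `C=C[C@@](C)(/C=C/c1ccc(OC(C)=O)cc1)CCC=C(C)C`, is the stronger of the two compounds measured in a functional assay on MCF7 cells (Homo sapiens) for inhibition, with a stated time of 48 h, tested at 50 uM; on this read-out higher numbers stand for more inhibition of growth at the one concentration tested and lower numbers for less inhibition of growth: compound 1 gives 75%, the higher of the two numbers known. Its closest neighbour, compound 2, `C=C[C@@](C)(/C=C/c1ccc(OC(=O)CCCC)cc1)CCC=C(C)C`, carries propyl in place of hydrogen on a saturated chain carbon bound to a carbonyl carbon, and in this assay compound 2 gives 25%. Among the measured compounds shown here, that single step, a number 50 percentage points lower from compound 1 to compound 2 (beyond the scatter), is the only measured comparison available.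

Compound 3, `C=C[C@@](C)(/C=C/c1ccc(OC(=O)CCCCC)cc1)CCC=C(C)C`, has not yet been measured. Compared with compound 1 it differs by butyl in place of hydrogen on a saturated chain carbon bound to a carbonyl carbon. For the measured compounds named here, the change sits at the same place as the one leading to compound 2, and the entering group is butyl rather than propyl, one carbon longer. The measured step to compound 2 therefore bears directly on it, and because a number 50 percentage points lower from compound 1 to compound 2 (beyond the scatter) was a large drop, a drop of similar size, and perhaps slightly greater, is expected for compound 3 as well, that is a number 55 percentage points lower from compound 1 to compound 3 (beyond the scatter). Compound 3 is thus estimated to give 20%, with a range from 5% to 40%.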

Compound 3, percent growth inhibition at one concentration: 18%
The estimate for compound 3 lay 2 percentage points above the measured number; the measured number falls inside the stated range.
By their numbers in this assay, from the lowest: compounds 3 and 2 (each within the scatter of the next); then compound 1.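

In this assay, butyl in place of hydrogen on a saturated chain carbon bound to a carbonyl carbon gives a number 57 percentage points lower from compound 1 to compound 3 (beyond the scatter), so the large loss at this place no longer rests on a single chain. The extra carbon at the end of the chain adds little to that loss: methyl in place of hydrogen on a saturated chain carbon, four bonds along the chain from a carbonyl carbon, gives a number 7 percentage points lower from compound 2 to compound 3 (within the scatter), and these two longer esters cannot be told apart in this read-out. Nothing available here accounts for the loss from the short acetoxy group to either longer ester.

The compounds shown leave open how the loss sets in between methyl and the longer chains, and an ethyl group at this place, giving a chain of intermediate length, would speak to whether it comes gradually or at once. They also leave open whether a still longer chain stays at this low level, and whether a branched tert-butyl group or a terminal amine or carboxylic acid on the chain would behave like these straight chains.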